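This account rests on a few compounds, and the source may have more. Where it says the series, first, only, none or still open, it means among the compounds named here.

Compound 1 `Cc1ccc(C(=O)CSc2nnc(C)n2N2C(=O)c3ccccc3C2=O)cc1` gives > 200000 nM in a functional assay on A549 cells (Homo sapiens) for cytotoxicity, read by MTT assay, with a stated time of 48 h (a higher number here means a weaker inhibitor, a lower number a stronger inhibitor), a limit of the assay.
Compound 2 `COc1cc(-c2nnc(SCC(=O)c3ccc(C)cc3)n2N2C(=O)c3ccccc3C2=O)cc(OC)c1OC` gives 6760 nM in this assay.

Compound 2 therefore holds the only number shown in this assay. Compound 1 sits at a limit, (the limit of > 200000 nM in this assay, at which 1 of the 2 values shown sits). Compound 3 `COc1ccc(C(=O)CSc2nnc(-c3cc(OC)c(OC)c(OC)c3)n2N2C(=O)c3ccccc3C2=O)cc1` differs from compound 2 by methoxy in place of methyl on an aromatic carbon. Among the measured compounds shown here, the single measured step, an at least 29-fold lower number from compound 1 to compound 2 (1.47 log units; beyond the scatter), concerns a different position of the shared core and does not bear on this exchange. For the measured compounds named here, with no measured step addressing the methyl to methoxy swap, compound 3 is expected to show a 1.0-fold lower number from compound 2 to compound 3 (0.02 log units; within the scatter), nothing beyond the usual scatter. The estimate for compound 3 is 6500 nM, ranging from 2500 nM to 17000 nM.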

Compound 3, half-maximal inhibitory concentration: 30000 nM
Estimate against measurement, compound 3: 4.6-fold (0.66 log units) below; the measured number lies above the stated range.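

Until now only a different position of the shared core had been varied; compound 3 shows that the group on the aromatic carbon para to a large group also matters in this assay, where methoxy in place of methyl gives a 4.4-fold higher number from compound 2 to compound 3 (0.65 log units; beyond the scatter), a modest step beyond the scatter. Of the two groups shown at this position, methyl goes with the lower number. Nothing given here points to a cause for this step. Open, from the compounds shown here alone, is whether a chlorine atom, a hydroxyl or an amine at this position would give a lower number than methyl. Also open, going by these compounds, is whether the step would hold with another group in place of the 3,4,5-trimethoxyphenyl.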